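Losing one methoxy: from compound 2 to compound 4

A few compounds are considered here, and "the series" means these few. Any claim that something is new, unique, unknown or untested is made for them only; others in the source may bear on it.

Measured in a functional assay on P388D1 cells (Homo sapiens) for antiproliferative activity, read by sulforhodamine B assay, with a stated time of 48 h; a lower number here means a stronger inhibitor, a higher number a weaker inhibitor:
- compound 1 `CCc1cccc(NS(=O)(=O)c2ccc(N3CCNC3=O)cc2)c1`: 250 nM
- compound 2 `COc1cc(NS(=O)(=O)c2ccc(N3CCNC3=O)cc2)cc(OC)c1OC`: 38 nM
- compound 3 `Cc1cc(C)cc(NS(=O)(=O)c2ccc(N3CCNC3=O)cc2)c1`: 210 nM

Compound 2 has the lowest number of the three, and the values of the other two both lie beyond the scatter from it. Compound 4 `COc1cc(NS(=O)(=O)c2ccc(N3CCNC3=O)cc2)cc(OC)c1` has yet to be measured. It differs from compound 2 by hydrogen in place of methoxy on an aromatic carbon, ortho to two methoxy groups and para to a large group.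

Among the measured compounds shown here, the only measured step between closely matched compounds is a 1.2-fold lower number from compound 1 to compound 3 (0.08 log units; within the scatter). It lies within the scatter and involves no methoxy group, so it offers no direct measure of this change. The expectation must therefore rest on a comparison of values alone, and that comparison is thin. For the measured compounds named here, an upward move is expected in this assay because compound 2 gives 38 nM as the only methoxy-bearing compound measured and compound 3 gives 210 nM without methoxy. Since two methoxy groups remain, only a moderate rise is expected, and the estimated step is a 3.9-fold higher number from compound 2 to compound 4 (0.60 log units; beyond the scatter). For compound 4 the estimated value is 150 nM, with an expected range from 50 nM to 450 nM.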

Compound 4, half-maximal inhibitory concentration: 200 nM
Estimate against measurement, compound 4: 1.3-fold (0.12 log units) below, within the range that was stated.
By their numbers in this assay, from the lowest: compound 2; then compounds 4, 3 and 1 (each within the scatter of the next).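

Among the compounds shown here, the step of a 5.3-fold higher number from compound 2 to compound 4 (0.72 log units; beyond the scatter) in this assay is the first direct measure at this position, and it lies beyond the scatter, whereas the only earlier matched step involved no methoxy group and stayed within it. It shows that the methoxy ortho to two methoxy groups and para to a large group matters in its own right: compound 4 keeps both of the other methoxy groups, yet it gives 200 nM where compound 2 gives 38 nM, so those two groups alone do not preserve the low number of compound 2. Nothing available explains why this single replacement has an effect of this size.

The compounds shown leave open whether it must be a methoxy on this carbon, or whether a hydroxyl, an ethoxy or an amine there would bring the number back towards that of compound 2. They also leave open how much each of the two remaining methoxy groups contributes when it is replaced by hydrogen on its own.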